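The compounds below may be only part of what the source reports. "The series", "measured", "known", "first", "only" and "open" are said of these compounds alone.

Compound 1 `CC(=O)Oc1ccc(-c2ccc(F)cc2F)cc1C(=O)O`: 0%
Compound 2 `CNC(=O)c1cc(-c2ccc(F)cc2F)ccc1OC(C)=O`: 29.9%
Compound 3 `CCNC(=O)c1cc(-c2ccc(F)cc2F)ccc1OC(C)=O`: 23.9%

In a functional assay on the whole organism (strain Kunming) for inhibition, with Mus musculus as the target, in the writhing test, at a dose of 40 mg/kg by the oral route (a higher number here means more inhibition at the dose given (going by the name of the read-out), a lower number less inhibition), compound 3 gives 23.9%, the second highest of the three numbers. Its nearest neighbour is compound 2, and a number 6 percentage points lower from compound 2 to compound 3 (within the scatter), so the two amides cannot be told apart here. The gap to compound 1 is real: a number 23.9 percentage points higher from compound 1 to compound 3 (beyond the scatter), and likewise a number 29.9 percentage points higher from compound 1 to compound 2 (beyond the scatter).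

Compound 4 `CC(=O)Oc1ccc(-c2ccc(F)cc2F)cc1C(=O)NC1CCCCC1` has not yet been tested. It differs from compound 3 by cyclohexyl in place of ethyl on an amide-type nitrogen, the place being an amide-type nitrogen whose other neighbour is the carbonyl carbon. Among the measured compounds shown here, of the measured steps, only the one from compound 2 to compound 3 touches the same nitrogen substituent, and a number 6 percentage points lower from compound 2 to compound 3 (within the scatter). The two steps from compound 1 describe a different change, the replacement of hydroxy by an amine on the carbonyl carbon, so they say little about growing the substituent further. With one relevant step lying within the scatter, the expectation for the step from compound 3 to compound 4 is modest: a number 1.9 percentage points lower from compound 3 to compound 4 (within the scatter) is expected, with no clear direction. Compound 4 is therefore estimated at 22%, between 6% and 38%.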

Compound 4, a percentage reported as inhibition, in the whole organism at one dose (the size of the read-out at that dose, not a potency): 15.6%
For compound 4 the middle estimate is 6.4 percentage points above the measured one; the measured number falls inside the stated range.
By their numbers in this assay, from the lowest: compound 1; then compounds 4, 3 and 2 (each within the scatter of the next, the first and the last beyond it).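

Putting a ring on this amide nitrogen, with cyclohexyl's 6 heavy atoms in place of the 2 of ethyl, gives in this assay a number 8.3 percentage points lower from compound 3 to compound 4 (within the scatter) and so cannot on its own be told apart from ethyl. The wider comparison at the same nitrogen does separate: swapping methyl for cyclohexyl gives a number 14.3 percentage points lower from compound 2 to compound 4 (beyond the scatter) and is the first change among these amides to clear the scatter, while all three substituents still differ from the hydroxy of the parent acid, with a number 15.6 percentage points higher from compound 1 to compound 4 (beyond the scatter) for the cyclohexyl amide. Nothing available explains why the larger ring group goes with less inhibition at this dose.

From the compounds shown here alone, what remains open is whether the ring itself matters or only the number of carbons, a question that an open-chain hexyl group on the same nitrogen could address. A plain unsubstituted amide, or a phenyl group in the same place, would also show whether the methyl amide marks the top of this series or just one point along it.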